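Swapping a hydroxymethyl for an oxime on the shared core

The compounds below may be only part of what the source reports. "The series", "measured", "known", "first", "only" and "open" are said of these compounds alone.

Compound 1 `Cc1ccc2c(Cc3nn4cc(-c5ccc(Cl)cc5)nc4s3)coc2c1` and compound 2 `Cc1ccc2c(Cc3nn4c(CO)c(-c5ccc(Cl)cc5)nc4s3)coc2c1` share one core and differ at a single aromatic carbon. In a functional assay on the whole organism (strain Wistar albino) for inhibition, with Rattus norvegicus as the target, read by paw edema, with a stated time of 4 h, at a dose of 100 mg/kg by the oral route (a higher number here means more inhibition at the dose given (going by the name of the read-out), a lower number less inhibition), compound 1 gives 55.9%. Compound 2 gives 54.3%, the lower of the two numbers shown, though only by a gap within the scatter. For the measured compounds named here, the one measured step, a number 1.6 percentage points lower from compound 1 to compound 2 (within the scatter), placed hydroxymethyl where hydrogen had been and hardly moved the read-out. Compound 3 `Cc1ccc2c(Cc3nn4c(/C=N/O)c(-c5ccc(Cl)cc5)nc4s3)coc2c1` carries a group of 3 heavy atoms (1 carbon, 1 nitrogen, 1 oxygen; no ring) in place of a group of 2 heavy atoms (1 carbon, 1 oxygen; no ring), on an aromatic carbon. Because the measured step of a number 1.6 percentage points lower from compound 1 to compound 2 (within the scatter) was small, no shift beyond the scatter is expected, and compound 3 is estimated at 54%, between 44% and 64%, a step of a number 0.3 percentage points lower from compound 2 to compound 3 (within the scatter).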

Compound 3, a percentage reported as inhibition, in the whole organism at one dose (the size of the read-out at that dose, not a potency): 11.1%
Estimate against measurement, compound 3: 42.9 percentage points above, outside the stated range (below it).
By their numbers in this assay, from the lowest: compound 3; then compounds 2 and 1 (each within the scatter of the next).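

This carbon accepts hydroxymethyl, but not every small group. In this assay the oxime gives a number 43.2 percentage points lower from compound 2 to compound 3 (beyond the scatter) and, measured against hydrogen, a number 44.8 percentage points lower from compound 1 to compound 3 (beyond the scatter) so the read-out depends on which group sits here, not merely on whether the carbon carries one. Nothing available explains this loss.

Going by these compounds, it remains open whether an amine, a carboxylic acid or a longer chain such as hydroxyethyl at this carbon would stay close to compound 2 or fall towards compound 3. The oxime's other double-bond geometry is also untested in the compounds shown.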